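This account rests on a few compounds, and the source may have more. Where it says the series, first, only, none or still open, it means among the compounds named here.

Compound 1 `O=S(=O)(Nc1ccc(-c2nc3ccccc3o2)cc1)c1ccc(Cl)c(C(F)(F)F)c1` gives 12000 nM in an assay on cells for inhibition of HSP60/HSP10 (Homo sapiens), with a stated time of 60 min; on this read-out lower numbers stand for stronger inhibition and higher numbers for weaker inhibition.
Compound 2 `COc1cccc(S(=O)(=O)Nc2ccc3oc(-c4ccccc4)nc3c2)c1` is recorded in this assay only as > 100000 nM, which is a limit of the assay and not a measured number.
Compound 3 `O=S(=O)(Nc1ccc(-c2nc3ccccc3o2)cc1)c1ccc(C(F)(F)F)cc1` gives 50000 nM in this assay.

Among the three measured compounds, compound 2 therefore stands apart from the other two: its result sits at the limit of > 100000 nM in this assay, at which 1 of the 3 values shown sits, so nothing can be said about how far beyond that limit its true half-maximal inhibitory concentration lies. Compound 1 and compound 3 both fall inside the range the assay can report, with compound 1 giving the lower of the two numbers.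

The unmeasured compound 4 `Cc1cccc(S(=O)(=O)Nc2ccc3oc(-c4ccccc4)nc3c2)c1` is built on the same core as compound 2 and differs from it by a single change: methyl in place of methoxy on an aromatic carbon. Among the measured compounds shown here, no pair of measured compounds shows the effect of this particular change, so the expectation for compound 4 rests on the position of compound 2 alone. Because compound 2 already sits at the limit of > 100000 nM in this assay, at which 1 of the 3 values shown sits, a step of no more than the usual scatter is anticipated in this assay, with no clear direction. Compound 4 is accordingly expected to give about 100000 nM, within a range of 30000 nM to 300000 nM, which corresponds to an expected step of a number no higher from compound 2 to compound 4 (the limit leaves the size open).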

Compound 4, half-maximal inhibitory concentration: > 100000 nM
Compound 4 was reported as a limit (the forecaster's own chance of this, stated with the estimate: 60%); the middle value sits exactly at the limit.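

Compound 2 and compound 4 are both recorded in this assay only as limits, so no step can be read between them, and the change from methoxy to methyl stays unreadable: the limit of > 100000 nM in this assay, at which 2 of the 4 values shown sit.
The compounds shown leave open how far beyond that limit each true half-maximal inhibitory concentration lies, and whether 3-methoxyphenyl and 3-methylphenyl differ at all.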